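Hydroxyphenyl-pyridines in HeLa cytotoxicity: thiophene for phenyl

The compounds below may be only part of what the source reports. "The series", "measured", "known", "first", "only" and "open" are said of these compounds alone.

Measured so far:
compound 1 `Oc1ccc(-c2cc(-c3ccccc3)cc(-c3ccccc3)n2)cc1`: 1700 nM
compound 2 `Oc1ccc(-c2cc(-c3ccccc3)cc(-c3cccs3)n2)cc1`: 1700 nM
compound 3 `Oc1cccc(-c2cc(-c3ccccc3)nc(-c3ccccc3)c2)c1`: 15100 nM

Three compounds of this series have been run in a functional assay on HeLa cells (Homo sapiens) for cytotoxicity, read by ELISA, with a stated time of 2 days; a higher number here means a weaker inhibitor, a lower number a stronger inhibitor. In this assay compound 1 gives 1700 nM and compound 2 gives 1700 nM. The two differ by one change, (thiophen-2-yl in place of phenyl on an aromatic carbon), and that change made a step of no change at the digits printed from compound 1 to compound 2 (within the scatter).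

Compound 3 gives 15100 nM in this assay, the highest of the three numbers, and its gap to compound 1 and to compound 2 lies beyond the scatter in both cases. Compound 3 has the same atoms as compound 1 joined differently; the difference between the two cores is not broken down here.

Compound 4 `Oc1cccc(-c2cc(-c3ccccc3)nc(-c3cccs3)c2)c1` has not yet been measured in this assay. It differs from compound 3 by thiophen-2-yl in place of phenyl on an aromatic carbon. Going by the values given here, this is the same kind of change as the one from compound 1 to compound 2, not the same change: around the place, compound 4 carries the thiophen-2-yl meta to a 3-hydroxyphenyl group, where compound 2 carries it meta to a 4-hydroxyphenyl group.

Among the compounds with values here, the only measured precedent is the step of no change at the digits printed from compound 1 to compound 2 (within the scatter), which stayed within the scatter. On that ground the step from compound 3 is expected to be a 1.0-fold lower number from compound 3 to compound 4 (0.00 log units; within the scatter). Compound 4 is therefore estimated at 15000 nM in this assay. Within the data shown here, the range expected for compound 4 runs from 6000 nM to 40000 nM, wide because the step of no change at the digits printed from compound 1 to compound 2 (within the scatter) is the only precedent and the core of compound 3 is not the core of compound 1.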

Compound 4, half-maximal inhibitory concentration: 15300 nM
Beside the measured number, compound 4's estimate is 1.0-fold (0.01 log units) below it; low and high end bracket the measured number.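

In this assay, thiophen-2-yl in place of phenyl on the core of compound 3 gives a 1.0-fold higher number from compound 3 to compound 4 (0.01 log units; within the scatter), so this swap, made on an aromatic carbon next to the ring nitrogen, leaves the read-out within the scatter on this core. The swap therefore carries over between the two cores without a detectable difference in its step: the same change on two cores in this assay, no change at the digits printed (within the scatter) from compound 1 to compound 2 and a 1.0-fold higher number (0.01 log units; within the scatter) from compound 3 to compound 4, 1.0-fold (0.01 log units) apart, within the scatter of two such steps. This rests on a single pair per core and on two steps that both stay within the scatter, so it shows that phenyl and thiophen-2-yl are interchangeable in this assay on these two cores only; it does not establish the same for any other core or for the other phenyl group, and it says nothing about what separates the core of compound 1 from the core of compound 3.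

Still open, from the compounds shown here alone, is whether another ring at this place, such as furan-2-yl or a phenyl carrying an amine, would also leave the number in this assay unmoved on both cores. Also open, going by these compounds, is how either core responds when a methoxy group or a carboxylic acid stands in place of the hydroxyl group.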